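A few compounds are considered here, and "the series" means these few. Any claim that something is new, unique, unknown or untested is made for them only; others in the source may bear on it.

Measured so far in a functional assay on HT-29 cells (Homo sapiens) for antiproliferative activity, read by sulforhodamine B assay, with a stated time of 48 h; a lower number here means a stronger inhibitor, a higher number a weaker inhibitor:
compound 1, `Cc1cccc(NS(=O)(=O)c2ccc(N3CCNC3=O)cc2)c1`, gives 110 nM
compound 2, `O=C1NCCN1c1ccc(S(=O)(=O)Nc2ccc(F)cc2)cc1`, gives 370 nM

Among the compounds with values here, compound 2 has the highest of the two numbers; its only neighbour is compound 1, and the step between them is a 3.4-fold higher number from compound 1 to compound 2 (0.53 log units; beyond the scatter).

Compound 3, `CCCCOc1ccc(NS(=O)(=O)c2ccc(N3CCNC3=O)cc2)cc1`, is not yet measured. It differs from compound 2 in one place: butoxy in place of fluoro on an aromatic carbon.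

Within the data shown here, the single known step, a 3.4-fold higher number from compound 1 to compound 2 (0.53 log units; beyond the scatter), concerns an exchange of the phenyl ring on the sulfonamide nitrogen and is the only guide here; it shows that a change on this ring can move the number beyond the scatter. Among the measured compounds shown here, no measured compound carries a butoxy group, so the direction for compound 3 is not fixed by the data. A move of moderate size is expected, more likely back toward the number of compound 1 than further up. The estimate for compound 3 is 200 nM, with a range from 60 nM to 700 nM. This estimate corresponds to an expected step of a 1.9-fold lower number from compound 2 to compound 3 (0.27 log units; within the scatter).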

Compound 3, half-maximal inhibitory concentration: 630 nM
Estimate against measurement, compound 3: 3.2-fold (0.50 log units) below; low and high end bracket the measured number.
By their numbers in this assay, from the lowest: compound 1; then compounds 2 and 3 (each within the scatter of the next).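

In this assay, butoxy in place of fluoro on the aromatic carbon para to a large group gives a 1.7-fold higher number from compound 2 to compound 3 (0.23 log units; within the scatter). Unlike the earlier exchange of the ring on the sulfonamide nitrogen, this change leaves the two numbers indistinguishable, so at this position a chain as large as butoxy is tolerated as well as a single fluoro atom. Nothing available explains this outcome.

As far as these compounds go, it remains open whether methoxy, an amine or a carboxylic acid on this carbon, or a chain longer than butoxy, would also stay within the scatter of compound 2. In a 3.4-fold higher number from compound 1 to compound 2 (0.53 log units; beyond the scatter), both the group and its place on the ring differ, so the contribution of each remains unresolved.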